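This account rests on a few compounds, and the source may have more. Where it says the series, first, only, none or still open, it means among the compounds named here.

Compound 1 `Cc1ccc(S(=O)(=O)Oc2ccccc2/C=C(\C#N)C(=O)Nc2nnc(Cc3ccccc3)s2)cc1`: 16%
Compound 2 `N#C/C(=C\c1ccccc1OS(=O)(=O)c1ccccc1[N+](=O)[O-])C(=O)Nc1nnc(Cc2ccccc2)s1`: 12%
Compound 3 `N#C/C(=C\c1ccccc1OS(=O)(=O)c1ccc(Cl)cc1)C(=O)Nc1nnc(Cc2ccccc2)s1`: 26%

In a functional assay on HL-60 cells (Homo sapiens) for inhibition, read by CCK-8 assay, with a stated time of 48 h, tested at 20 uM (on this read-out lower numbers stand for less inhibition of growth and higher numbers for more inhibition of growth at the one concentration tested), compound 3 stands clearly apart from only one of the other two compounds: the data show a number 14 percentage points higher from compound 2 to compound 3 (beyond the scatter), but a number 10 percentage points higher from compound 1 to compound 3 (within the scatter). Compound 4 `N#C/C(=C\c1ccccc1OS(=O)(=O)c1ccc(Cl)cc1)C(=O)Nc1nnc(Cc2ccc(Cl)cc2)s1` changes the benzyl of compound 3 to 4-chlorobenzyl, with chloro in place of hydrogen on an aromatic carbon. Within the data shown here, no measured step touches this group. The closest guide is the step that brought in chloro, in place of methyl, in another part of the molecule, a number 10 percentage points higher from compound 1 to compound 3 (within the scatter). This guide is weak, and no shift beyond the scatter is expected. The expected outcome is a number 4 percentage points higher from compound 3 to compound 4 (within the scatter). For compound 4 the estimated value is 30%, with an expected range from 14% to 50%.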

Compound 4, percent growth inhibition at one concentration: 15%
For compound 4 the middle estimate is 15 percentage points above the measured one, within the range that was stated.
By their numbers in this assay, from the lowest: compounds 2, 4, 1 and 3 (each within the scatter of the next, the first and the last beyond it).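

Putting chloro in place of hydrogen on the benzyl ring gives a number 11 percentage points lower from compound 3 to compound 4 (beyond the scatter) in this assay. Among these compounds, the earlier steps changed only the group on the sulfonyl sulfur, so this is the first sign that the benzyl end also affects growth inhibition at the one concentration tested, and that a single added atom there is enough. Nothing measured here explains the drop.

Whether it is specific to chloro stays open, as the compounds shown do not tell how a methoxy group or an amine at this place would compare. It is also unknown whether chloro would lower the number with 4-methylphenyl on the sulfonyl sulfur.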